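From methoxy to trifluoromethyl on a short-lived compound

A few compounds are considered here, and "the series" means these few. Any claim that something is new, unique, unknown or untested is made for them only; others in the source may bear on it.

Among the measured compounds shown here, in a physicochemical assay for pharmacokinetics (a higher number here means that the compound lasts longer, a lower number that the compound disappears faster), compound 1 `COc1ccc(CNC(=O)N2C(=O)c3ccccc3S2(=O)=O)cc1` gives 0.187 h, the lower of the two numbers so far, while compound 2 `COc1cccc(CNC(=O)N2C(=O)c3ccccc3S2(=O)=O)c1` gives 0.523 h. Compound 3 `O=C(NCc1ccc(C(F)(F)F)cc1)N1C(=O)c2ccccc2S1(=O)=O` has not yet been measured. It differs from compound 1 in one place, with trifluoromethyl in place of methoxy on an aromatic carbon, para to a large group (trifluoromethyl in place of methoxy on an aromatic carbon).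

For the measured compounds named here, only one measured step bears on this change, and it does so indirectly: a 2.8-fold higher number from compound 1 to compound 2 (0.45 log units; beyond the scatter). That step relocates the methoxy group and does not replace it, so it shows that a change on this ring can shift the half-life but says nothing about trifluoromethyl itself. With so little evidence, a rise in this assay somewhat smaller than that step is expected, and neither no change nor a small fall can be excluded. The expected move is a 2.1-fold higher number from compound 1 to compound 3 (0.33 log units; beyond the scatter), close to the edge of the scatter. For compound 3 the estimated half-life is 0.4 h, with an expected range from 0.13 h to 1.2 h.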

Compound 3, half-life: 0.212 h
Compound 3: the middle estimate sits 1.9-fold (0.28 log units) above what was measured; the range from low to high includes it.
By their numbers in this assay, from the lowest: compounds 1 and 3 (each within the scatter of the next); then compound 2.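

In this assay, trifluoromethyl in place of methoxy on an aromatic carbon, para to a large group, gives a 1.1-fold higher number from compound 1 to compound 3 (0.05 log units; within the scatter), so compound 1 and compound 3 cannot be told apart. Among the compounds shown here, the earlier pair showed only that relocating the methoxy group could matter, with a 2.8-fold higher number from compound 1 to compound 2 (0.45 log units; beyond the scatter); this pair shows that, at this place, methoxy can be exchanged for a group with different atoms and without its hydrogen-bond acceptor, and the half-life stays within the scatter. No measurement is available that would explain why the two half-lives cannot be separated.

The compounds shown leave open whether trifluoromethyl would give a similar reading on the ring carbon that carries the methoxy group in compound 2, the only change so far that has gone beyond the scatter in this assay. They also leave open whether this place would tolerate other groups as well, such as an amine, a carboxylic acid or a longer chain, or whether the match between methoxy and trifluoromethyl is particular to this pair.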